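The source may hold more compounds than are shown below. What is called first, only, known or untested is meant among the compounds shown, and "the series" means these compounds.

Of the compounds shown here, three on one shared core have been measured so far in a functional assay on MDA-MB-435 cells (Homo sapiens) for cytotoxicity, read by MTT assay, with a stated time of 5 days (a lower number here means a stronger inhibitor, a higher number a weaker inhibitor), and they differ only in one side chain. Compound 1 (`CCOc1cc(C(C)(C)C)ccc1C1=N[C@@](C)(c2ccc(Cl)cc2)[C@@](C)(c2ccc(Cl)cc2)N1C(=O)N1CCN(CCC(F)(F)F)CC1`) gives 29300 nM here, compound 2 (`CCOc1cc(C(C)(C)C)ccc1C1=N[C@@](C)(c2ccc(Cl)cc2)[C@@](C)(c2ccc(Cl)cc2)N1C(=O)N1CCN(CCNS(C)(=O)=O)CC1`) gives 7300 nM here, and compound 3 (`CCOc1cc(C(C)(C)C)ccc1C1=N[C@@](C)(c2ccc(Cl)cc2)[C@@](C)(c2ccc(Cl)cc2)N1C(=O)N1CCN(CCNC(C)=O)CC1`) gives 10500 nM here. Compound 3 cannot be told apart from compound 2, and only compound 1 stands clear of it. The data show a 4.0-fold lower number from compound 1 to compound 2 (0.60 log units; beyond the scatter) and a 2.8-fold lower number from compound 1 to compound 3 (0.45 log units; beyond the scatter) but only a 1.4-fold higher number from compound 2 to compound 3 (0.16 log units; within the scatter) for the swap of acetyl in place of methylsulfonyl on an amine nitrogen.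

Compound 4 (`CCOc1cc(C(C)(C)C)ccc1C1=N[C@@](C)(c2ccc(Cl)cc2)[C@@](C)(c2ccc(Cl)cc2)N1C(=O)N1CCN(CC(=O)N2CCCC2)CC1`) is the next to be tested and carries this change from compound 3: (pyrrolidin-1-yl)carbonyl in place of acetamidomethyl on a saturated chain carbon bound to an amine nitrogen in a ring (in words, (pyrrolidin-1-yl)carbonyl in place of acetamidomethyl on a saturated chain carbon bound to an amine nitrogen in a ring). Within the data shown here, no measured step makes this exact exchange. The two larger steps start from the trifluoromethyl chain of compound 1, which compound 4 does not share. The closest guide is the small step of a 1.4-fold higher number from compound 2 to compound 3 (0.16 log units; within the scatter) between two chains that both hold an amide-type group. The expectation is therefore a 1.1-fold higher number from compound 3 to compound 4 (0.06 log units; within the scatter) in this assay and so nothing beyond the scatter. For compound 4 the expected value is 12000 nM with an estimated range from 5500 nM to 26000 nM overall.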

Compound 4, half-maximal inhibitory concentration: 9500 nM
Estimate against measurement, compound 4: 1.3-fold (0.10 log units) above; measured number inside the range.
By their numbers in this assay, from the lowest: compounds 2, 4 and 3 (each within the scatter of the next); then compound 1.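

In this assay, replacing acetamidomethyl with (pyrrolidin-1-yl)carbonyl gives a 1.1-fold lower number from compound 3 to compound 4 (0.04 log units; within the scatter), and replacing (methanesulfonamido)methyl with the same group gives a 1.3-fold higher number from compound 2 to compound 4 (0.11 log units; within the scatter); at this place, then, a chain with 0 hydrogen-bond donors and one five-membered non-aromatic ring cannot be told apart from the two chains that each keep a hydrogen on the nitrogen of an amide-type group. The step against the 2,2,2-trifluoroethyl group, a 3.1-fold lower number from compound 1 to compound 4 (0.49 log units; beyond the scatter), is beyond the scatter, so the separation of compound 1 from the others now holds for three polar-free-of-judgement-neutral chains of differing build rather than for two closely related ones. Nothing available explains the flat result among compound 2, compound 3 and compound 4, or the separation of compound 1 from them.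

The compounds shown leave open whether a 2-(dimethylamino)ethyl chain, a carboxylic acid or a longer chain ending in a pyrrolidine amide at this place would stay with compound 2, compound 3 and compound 4 or move clear of them. They also leave open whether a chain with a ring but still carrying an amide hydrogen, such as a (piperidin-4-yl)carbonyl group, would read the same way in this assay.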